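Removing the 4-methylphenoxy group from compound 3

This account rests on a few compounds, and the source may have more. Where it says the series, first, only, none or still open, it means among the compounds named here.

Values measured so far in a functional assay on HCT-116 cells (Homo sapiens) for antiproliferative activity, read by MTT assay, with a stated time of 48 h (a higher number here means a weaker inhibitor of growth, a lower number a stronger inhibitor of growth), are as follows
- compound 1 `CCCCCN(Cc1ccc(C(=O)NO)cc1)c1ncc(-c2ccc(C)cc2)s1` gives 23300 nM
- compound 2 `Cc1ccc(-c2cnc(N(Cc3ccccc3)Cc3ccc(C(=O)NO)cc3)s2)cc1` gives 48800 nM
- compound 3 `Cc1ccc(OCCCCN(Cc2ccc(C(=O)NO)cc2)c2ncc(-c3ccc(C)cc3)s2)cc1` gives 580 nM

Compound 3 has the lowest number of the three at 580 nM and so is the strongest growth inhibitor among them. The next compound, compound 4 `CCCCN(Cc1ccc(C(=O)NO)cc1)c1ncc(-c2ccc(C)cc2)s1`, differs from it by one change hydrogen in place of 4-methylphenoxy on a saturated chain carbon, four bonds along the chain from a nitrogen on an aromatic ring which puts hydrogen in place of 4-methylphenoxy on a saturated chain carbon, four bonds along the chain from a nitrogen on an aromatic ring.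

The closest guide is a 40-fold lower number from compound 1 to compound 3 (1.60 log units; beyond the scatter) where 4-methylphenoxy takes the place of methyl at that same chain position. Also large is an 84-fold lower number from compound 2 to compound 3 (1.92 log units; beyond the scatter) while the remaining step is only modest, a 2.1-fold higher number from compound 1 to compound 2 (0.32 log units; beyond the scatter) and both compounds lacking the 4-methylphenoxy group sit high. In this assay the expected change is a large rise of similar size, estimated as a 43-fold higher number from compound 3 to compound 4 (1.63 log units; beyond the scatter) and not a shift within the scatter. Compound 4 is expected at 25000 nM (estimated range 10000 nM to 60000 nM).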

Compound 4, concentration for 50% growth inhibition: 8780 nM
Estimate against measurement, compound 4: 2.8-fold (0.45 log units) above; measured number below the stated range.
By their numbers in this assay, from the lowest: compound 3; then compound 4; then compound 1; then compound 2.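

Against a plain butyl chain, the 4-methylphenoxy group still counts in this assay, with a 15-fold higher number from compound 3 to compound 4 (1.18 log units; beyond the scatter) when it is removed, though this step is smaller than the one seen against the pentyl chain of compound 1. The plain chain is not neutral either: there is a 2.7-fold lower number from compound 1 to compound 4 (0.42 log units; beyond the scatter) when pentyl is shortened to butyl, so part of the earlier contrast came from the extra methyl of compound 1. With a 5.6-fold lower number from compound 2 to compound 4 (0.74 log units; beyond the scatter) on putting propyl in place of phenyl, compound 4 has the lowest number of the compounds lacking 4-methylphenoxy, yet compound 3 remains lower.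

No evidence is at hand on why these numbers shift. Still open, as far as these compounds go, is which part of the 4-methylphenoxy group carries the gain: the ether oxygen, the ring or its methyl, as a plain phenoxy or a 4-methylphenyl group would show, and whether a propyl chain would continue the trend from pentyl to butyl.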